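A bicyclic replacement on the benzylic position of compound 1

The compounds below may be only part of what the source reports. "The series", "measured", "known", "first", "only" and "open" are said of these compounds alone.

Among the measured compounds shown here, compound 1 `CNC(=O)c1cc(C(=O)NC2CC2)cn(Cc2cccc(OC)c2)c1=O` is the only one of the three compounds with a number in a physicochemical assay for solubility (a lower number here means a less soluble compound, a higher number a more soluble compound), where compound 1 gives 79 ug/mL. Compound 2 `CNC(=O)c1cc(C(=O)NC2CCC2)cn(Cc2cccc(NC)c2)c1=O` reaches only a limit of the assay in this assay, giving >= 155 ug/mL. Compound 3 `CCNC(=O)c1cc(C(=O)NC)c(=O)n(Cc2ccccc2)c1` likewise gives a limit in this assay, namely >= 144 ug/mL. For the measured compounds named here, no step between measured compounds that differ in a single place is available here. Compound 4 `CNC(=O)c1cc(C(=O)NC2CC2)cn(Cc2nccc3[nH]ccc23)c1=O` is not yet measured; it differs from compound 1 by a group of 9 heavy atoms (7 carbon, 2 nitrogen; one five-membered aromatic ring with 1 hetero atom, one six-membered aromatic ring with 1 hetero atom) in place of a group of 8 heavy atoms (7 carbon, 1 oxygen; one six-membered aromatic ring of carbon only), on a saturated chain carbon bound to an aromatic nitrogen. For this change a modest rise in this assay is expected, of a size close to the usual scatter, and the estimated step of a 1.5-fold higher number from compound 1 to compound 4 (0.18 log units; within the scatter) expresses that expectation. Compound 4 is therefore estimated at 120 ug/mL, with a range from 50 ug/mL to 300 ug/mL.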

Compound 4, solubility: 73 ug/mL
For compound 4 the middle estimate is 1.6-fold (0.22 log units) above the measured one, and the stated range covers the measured number.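

On a saturated chain carbon bound to an aromatic nitrogen, this assay now has its first comparison in a single place, and it gives a 1.1-fold lower number from compound 1 to compound 4 (0.03 log units; within the scatter). The 3-methoxyphenyl can thus give way to a group with a five-membered and a six-membered aromatic ring, which carries a hydrogen-bond donor, with the two compounds staying within the scatter of each other. Nothing measured here gives a reason for this outcome.

As far as these compounds go, whether an amine or a carboxylic acid at this place would give a number apart from compound 1 remains open.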